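Trimming the amine of compound 1 to dimethylamino

The compounds below may be only part of what the source reports. "The series", "measured", "known", "first", "only" and "open" are said of these compounds alone.

For the measured compounds named here, compound 1 `O=C1CCc2ccc(OCCCN3CCCCC3)cc2N1Cc1ccccc1` is one of three compounds measured in an assay on cell membranes (strain Dunkin Hartley) for displacement of a labelled ligand from Sigma non-opioid intracellular receptor 1 (Cavia porcellus), read by scintillation counting, with a stated time of 180 min (on this read-out higher numbers stand for weaker inhibition and lower numbers for stronger inhibition), where compound 1 gives 1.84 nM. Among the three numbers compound 1 stands second highest. Its nearest neighbour is compound 2 `CC1CCN(CCCOc2ccc3c(c2)N(Cc2ccccc2)C(=O)CC3)CC1`, which in this assay gives 1.1 nM; the step of a 1.7-fold lower number from compound 1 to compound 2 (0.22 log units; within the scatter) is within the scatter. The furthest is compound 3 `O=C1CCc2ccc(OCCCN3CCN(c4ccccc4)CC3)cc2N1Cc1ccccc1`, which in this assay gives 341 nM, a number far above that of compound 1 and beyond the scatter.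

The next compound, compound 4 `CN(C)CCCOc1ccc2c(c1)N(Cc1ccccc1)C(=O)CC2`, differs from compound 1 in a single place: dimethylamino in place of piperidin-1-yl on a saturated chain carbon, three bonds along the chain from an oxygen on an aromatic ring. Going by the values given here, no measured step matches this change. The step from compound 1 to compound 2 concerns a methyl on the saturated ring and is within the scatter, so it says little about removing the ring itself. Among the compounds with values here, compound 3 shows that a larger replacement of the amine gave a much higher number, but no step is computed for that pair. With nothing directly bearing on the change, a modest rise in this assay is expected for compound 4, with the step estimated as a 3.8-fold higher number from compound 1 to compound 4 (0.58 log units; beyond the scatter). Compound 4 is therefore expected to give about 7 nM, within a range of 2 nM to 30 nM.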

Compound 4, inhibition constant: 83.2 nM
Estimate against measurement, compound 4: 12-fold (1.08 log units) below, outside the stated range (above it).
By their numbers in this assay, from the lowest: compounds 2 and 1 (each within the scatter of the next); then compound 4; then compound 3.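

In this assay this position proves far from indifferent to the amine: replacing piperidin-1-yl, with its 6 heavy atoms and one six-membered non-aromatic ring, by dimethylamino, with 3 heavy atoms and no ring, gives a large rise (a 45-fold higher number from compound 1 to compound 4 (1.66 log units; beyond the scatter)), whereas adding a methyl to the saturated ring stays within the scatter (a 1.7-fold lower number from compound 1 to compound 2 (0.22 log units; within the scatter)). The same exchange made from 4-methylpiperidin-1-yl is also large (a 76-fold higher number from compound 2 to compound 4 (1.88 log units; beyond the scatter)), so the loss of affinity appears from both ring-bearing starting points, and the open-chain amine stands well apart from compounds 1 and 2. A ring at this place does not suffice on its own, however, as compound 3, whose amine also carries a ring, gives 341 nM.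

Nothing available explains why the exchange has so large an effect. The compounds shown leave open whether the ring itself or only the number of carbons around the nitrogen decides the outcome, which diethylamino, pyrrolidin-1-yl or azepan-1-yl on the same 3-carbon propyl chain would help to separate.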